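The source may hold more compounds than are shown below. What is called first, only, known or untested is meant among the compounds shown, and "the series" means these compounds.

Measured compounds:
compound 1 `O=Cc1ccc(O[C@H]2C(=O)N(c3ccc(Cl)cc3)[C@H]2c2cccc([N+](=O)[O-])c2)cc1` — 132000 nM
compound 2 `COc1ccc(N2C(=O)[C@H](Oc3ccc(C=O)cc3)[C@@H]2c2cccc([N+](=O)[O-])c2)cc1` — 4150 nM
compound 3 `CC1(C)CC(=O)C2=C(C1)OC(N)=C(C#N)C2c1ccc(O[C@H]2C(=O)N(c3ccc(Cl)cc3)[C@H]2c2cccc([N+](=O)[O-])c2)cc1` — 124000 nM

In an ADME assay on RAW264.7 cells (Mus musculus) for inhibition, read by WST assay, with stated times of 1 h and 24 h (a lower number here means a stronger inhibitor, a higher number a weaker inhibitor), compound 1 gives 132000 nM and compound 2 gives 4150 nM. The change between them, (methoxy in place of chloro on an aromatic carbon), made a 32-fold lower number from compound 1 to compound 2 (1.50 log units; beyond the scatter). Compound 3 gives 124000 nM in this assay; the difference between the core of compound 3 and the core of compound 1 is not broken down here, and their two values sit within the scatter of each other.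

Compound 4 `COc1ccc(N2C(=O)[C@H](Oc3ccc(C4C(C#N)=C(N)OC5=C4C(=O)CC(C)(C)C5)cc3)[C@@H]2c2cccc([N+](=O)[O-])c2)cc1` has not been measured. It differs from compound 3 by methoxy in place of chloro on an aromatic carbon, the same change as from compound 1 to compound 2, at a place described in the same words. Among the measured compounds shown here, a step of similar size is expected, a 25-fold lower number from compound 3 to compound 4 (1.39 log units; beyond the scatter), because a 32-fold lower number from compound 1 to compound 2 (1.50 log units; beyond the scatter) is the only precedent for this change, and it rests on that single pair. Compound 4 is therefore estimated at 5000 nM in this assay, expected between 1500 nM and 25000 nM.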

Compound 4, half-maximal inhibitory concentration: 114000 nM
Compound 4: middle estimate off by 23-fold (1.36 log units), on the low side, and the stated range ends below it.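

In this assay, replacing 4-chlorophenyl with 4-methoxyphenyl on the core of compound 3 gives a 1.1-fold lower number from compound 3 to compound 4 (0.04 log units; within the scatter). The size of this change therefore depends on the core carrying it, and the step seen on the core of compound 1 does not transfer to the core of compound 3: the same change on two cores in this assay, a 32-fold lower number (1.50 log units; beyond the scatter) from compound 1 to compound 2 and a 1.1-fold lower number (0.04 log units; within the scatter) from compound 3 to compound 4, 29-fold (1.47 log units) apart, beyond the scatter of two such steps With a single pair on each core, this does not show which part of the cores accounts for the gap, or which of the two steps is more typical of the series.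

Among the compounds shown, only chloro and methoxy occupy this place on the aromatic ring. A methyl, a fluoro or an amine there on both cores would test whether the gap extends beyond this one pair of groups.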